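Replacing phenoxy with 4-aminophenyl on the quinazolinedione-type scaffold

The source may hold more compounds than are shown below. What is called first, only, known or untested is meant among the compounds shown, and "the series" means these compounds.

Three analogues sharing one core were measured in a functional assay on PANC-1 cells (Homo sapiens) for cytotoxicity, read by MTT assay, with a stated time of 72 h; on this read-out lower numbers stand for stronger inhibition and higher numbers for weaker inhibition. Compound 2 `O=C1C(Nc2ccc(Oc3ccccc3)cc2)=CC(=O)c2ncncc21` gives 1800 nM and stands lowest of the three. Compound 1 `Cc1ccc(-c2ccc(NC3=CC(=O)c4ncncc4C3=O)cc2F)cc1` gives 4800 nM, and compound 3 `COc1cc(NC2=CC(=O)c3ncncc3C2=O)cc(OC)c1` gives 7200 nM; both gaps to compound 2 lie beyond the scatter. The unmeasured compound 4 `Nc1ccc(-c2ccc(NC3=CC(=O)c4ncncc4C3=O)cc2)cc1` differs from compound 2 by 4-aminophenyl in place of phenoxy on an aromatic carbon. Among the compounds with values here, no measured pair isolates this change, so its effect is unknown; compound 1, which also carries a directly attached aromatic ring, gives a higher number than compound 2, which suggests the step could move upward. Compound 4 is therefore expected to reach 3000 nM, within 1000 nM to 9000 nM, a modest expected weakening of a 1.7-fold higher number from compound 2 to compound 4 (0.22 log units; within the scatter) that may still fall within the scatter.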

Compound 4, half-maximal inhibitory concentration: 3700 nM
Compound 4: middle estimate off by 1.2-fold (0.09 log units), on the low side, and the stated range covers the measured number.
By their numbers in this assay, from the lowest: compound 2; then compounds 4, 1 and 3 (each within the scatter of the next).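

In this assay, within the data shown here, 4-aminophenyl in place of phenoxy, on an aromatic carbon para to a large group, gives a 2.1-fold higher number from compound 2 to compound 4 (0.31 log units; beyond the scatter), the first step at this position that isolates a single change. The two groups have the same heavy-atom count, yet the exchange of oxygen for nitrogen and the added hydrogen-bond donor come with a measurable change in the number. Nothing available explains this step. Going by these compounds, a plain phenyl or a 4-hydroxyphenyl at this place remains open, so the step cannot yet be divided between losing the ether oxygen and gaining the amine.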